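The compounds below may be only part of what the source reports. "The series", "measured", "known", "first", "only" and "open" are said of these compounds alone.

Compound 2 `CCC(=O)N[C@@H]1CCCc2c1cncc2N1C(=O)c2ccc(Cl)cc2[C@H]1CC` carries an ethyl on the saturated ring carbon of the shared core; in an assay on cells for inhibition of cytochrome P450 11B2, mitochondrial (Homo sapiens), read by HTRF (a higher number here means a weaker inhibitor, a lower number a stronger inhibitor), compound 2 gives 90 nM. Within the data shown here, this is the higher of the two numbers measured so far. The other measured member, compound 1 `CCC(=O)N[C@@H]1CCCc2c1cncc2N1C(=O)c2ccc(Cl)cc2[C@@H]1C`, gives 6 nM in this assay, and the gap between these two values lies beyond the usual scatter. The next step leads to compound 3 `CCC(=O)N[C@@H]1CCCc2c1cncc2N1C(=O)c2ccc(Cl)cc2[C@H]1C`, which differs from compound 2 by hydrogen in place of methyl on a saturated chain carbon bound to a saturated ring carbon; cut one bond further out, the difference reads ethyl to methyl. Among the measured compounds shown here, no measured pair repeats this change, so its size is not known from the data. With only compound 1 and compound 2 as reference points, a moderate move toward a lower number is expected, but with wide uncertainty. Compound 3 is estimated at 40 nM in this assay, within a range of 8 nM to 200 nM. The expected step is then a 2.3-fold lower number from compound 2 to compound 3 (0.35 log units; beyond the scatter).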

Compound 3, half-maximal inhibitory concentration: 66 nM
Compound 3: middle estimate off by 1.7-fold (0.22 log units), on the low side; low and high end bracket the measured number.
By their numbers in this assay, from the lowest: compound 1; then compounds 3 and 2 (each within the scatter of the next).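

In this assay, the change from methyl to hydrogen on a saturated chain carbon bound to a saturated ring carbon, which reads as ethyl to methyl when cut one bond further out, gives a 1.4-fold lower number from compound 2 to compound 3 (0.13 log units; within the scatter). This step lies within the scatter, so with this drawn configuration the two chain lengths cannot be told apart. Configuration gives the large step instead, an 11-fold higher number from compound 1 to compound 3 (1.04 log units; beyond the scatter), and this step involves no change of atoms or bonds: the fact that compounds 1 and 3 differ only in the configuration as drawn.

As far as these compounds go, it remains open whether ethyl drawn in the configuration of compound 1 would follow methyl to a low number. From the compounds shown here alone, it is also open whether a longer chain such as propyl, or an amine at this carbon, would show the same dependence on configuration.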